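The compounds below may be only part of what the source reports. "The series", "measured", "known", "first", "only" and "open" are said of these compounds alone.

Of the compounds shown here, three of one shared core have been tested in a functional assay on Ehrlich cells (Mus musculus) for cytotoxicity, tested at 100 ug/mL; a lower number here means a weaker effect, a higher number a stronger effect of the compound at the concentration tested. Compound 1 `COc1cc(N2C(N)=C(C#N)C(c3ccc([N+](=O)[O-])cc3)C3=C2CC(C)(C)CC3=O)cc(OC)c1OC` gives 80%. Compound 2 `COc1ccc(C2C(C#N)=C(N)N(c3cc(OC)c(OC)c(OC)c3)C3=C2C(=O)CC(C)(C)C3)cc1` gives 15%. Compound 3 `COc1cc(N2C(N)=C(C#N)C(c3c(OC)ccc4ccccc34)C3=C2CC(C)(C)CC3=O)cc(OC)c1OC` gives 30%, which places compound 3 second highest of the three: compound 2 sits closest, and compound 1 furthest above it.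

The steps among the measured compounds are all on the aryl group attached to the saturated ring carbon. The step of a number 65 percentage points lower from compound 1 to compound 2 (beyond the scatter) and the step of a number 50 percentage points lower from compound 1 to compound 3 (beyond the scatter) were both large, while the step of a number 15 percentage points higher from compound 2 to compound 3 (beyond the scatter) was modest.

Compound 4 `COc1cc(N2C(N)=C(C#N)C(c3cccs3)C3=C2CC(C)(C)CC3=O)cc(OC)c1OC` differs from compound 3 as follows: thiophen-2-yl in place of 2-methoxynaphthalen-1-yl on a saturated ring carbon. Within the data shown here, the steps that bear on this change are those on the same saturated ring carbon, namely a number 50 percentage points lower from compound 1 to compound 3 (beyond the scatter) and a number 15 percentage points higher from compound 2 to compound 3 (beyond the scatter). These show that compound 1 stands well above the other two, and that compound 2 and compound 3, which both carry a methoxy-bearing aryl group, lie close to each other at the low end. Nothing measured here speaks to a thiophen-2-yl group, so a small step in either direction is expected, and compound 4 is expected to come out near compound 3, with the step of a number 5 percentage points lower from compound 3 to compound 4 (within the scatter) estimated to lie within the scatter. Compound 4 is therefore estimated at 25%, in the range from 10% to 50%.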

Compound 4, a percentage reported as activity, at one concentration (the size of the read-out at that concentration, not a potency): 20%
For compound 4 the middle estimate is 5 percentage points above the measured one, and the stated range covers the measured number.
By their numbers in this assay, from the lowest: compounds 2, 4 and 3 (each within the scatter of the next, the first and the last beyond it); then compound 1.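

In this assay, exchanging the 2-methoxynaphthalen-1-yl group of 12 heavy atoms for the thiophen-2-yl group of 5 heavy atoms gives a number 10 percentage points lower from compound 3 to compound 4 (within the scatter), and exchanging the 4-methoxyphenyl group for thiophen-2-yl gives a number 5 percentage points higher from compound 2 to compound 4 (within the scatter). This position on the saturated ring carbon thus accepts a five-membered aromatic ring with a sulfur atom, a single six-membered carbon ring or a fused pair of such rings, and compound 4 cannot be separated from either compound 2 or compound 3, although those two lie beyond the scatter of each other. With a number 60 percentage points lower from compound 1 to compound 4 (beyond the scatter) added to the earlier steps, the 4-nitrophenyl group of compound 1 stands apart from all three other groups at this position, and no information here accounts for that gap.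

The compounds shown leave open whether that gap belongs to the nitro group itself, since an unsubstituted phenyl, a 4-chlorophenyl or a 4-cyanophenyl group does not appear among them. They also leave open whether a nitro group elsewhere on the phenyl ring, or a 5-nitrothiophen-2-yl group, would stand with compound 1 or with the other three.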